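This account rests on a few compounds, and the source may have more. Where it says the series, first, only, none or still open, it means among the compounds named here.

Of the compounds shown here, two built on one shared core have so far been tested in a functional assay on U-87MG ATCC cells (Homo sapiens) for cytotoxicity, read by MTT assay, with a stated time of 72 h; on this read-out lower numbers stand for stronger inhibition and higher numbers for weaker inhibition. Compound 1, `CN(C)CCn1cnnc1-c1cc(Oc2ccc(NC(=O)N/N=C/c3cc(C(C)(C)C)cc(C(C)(C)C)c3O)cc2F)ccn1`, gives 520 nM. Compound 2, `CN(C)CCn1cnnc1-c1cc(Oc2ccc(NC(=O)N/N=C/c3ccccc3)cc2F)ccn1`, gives 2250 nM, the higher of the two numbers and therefore the weaker inhibitor of the pair. Compound 3, `CN(C)CCn1cnnc1-c1cc(Oc2ccc(NC(=O)N/N=C/c3cc(Br)c(O)c(Br)c3)cc2F)ccn1`, has not been measured; it differs from compound 2 by 3,5-dibromo-4-hydroxyphenyl in place of phenyl on a carbon with a double bond to nitrogen. Compound 1 again stands at 520 nM. On that basis the step of a 3.2-fold lower number from compound 2 to compound 3 (0.51 log units; beyond the scatter) is expected, toward stronger inhibition and beyond the usual scatter. For compound 3 the estimate in this assay is 700 nM, with a range from 250 nM to 2000 nM.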

Compound 3, half-maximal inhibitory concentration: > 100000 nM
Compound 3 ended at the assay's limit; the forecaster's own chance of this, stated with the estimate: 3%; middle value at least 140-fold (2.15 log units) from the limit.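

In this assay, the group on this carbon can change the result sharply: 3,5-dibromo-4-hydroxyphenyl in place of phenyl gives an at least 44-fold higher number from compound 2 to compound 3 (1.64 log units; beyond the scatter). The value of compound 3 is a limit of the assay, not a number: the limit of > 100000 nM in this assay, at which 1 of the 3 values shown sits. A substituted phenyl ring here therefore does not by itself bring stronger inhibition, as compound 1 at 520 nM might have suggested. Still open, going by these compounds, is whether the two bromines, the hydroxyl or their combination accounts for the step. A 4-hydroxyphenyl or a 3,5-dibromophenyl group on this carbon would help separate them.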